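One added methoxy on a bromo compound

The compounds below may be only part of what the source reports. "The series", "measured", "known", "first", "only" and "open" are said of these compounds alone.

Compound 1 `COc1cc(/C=C2\CN(C)C/C(=C\c3ccc(Cl)cc3)C2=O)cc(OC)c1`: 5950 nM
Compound 2 `COc1cc(/C=C2\CN(C)C/C(=C\c3ccc(Br)cc3)C2=O)cc(OC)c1`: 4840 nM

In a functional assay on HepG2 cells (Homo sapiens) for cytotoxicity, read by MTT assay, with a stated time of 24 h (a lower number here means a stronger inhibitor, a higher number a weaker inhibitor), compound 2 gives 4840 nM, and compound 1 lies within the scatter of it, so neither number stands apart. Compound 3 `COc1cc(/C=C2\CN(C)C/C(=C\c3ccc(Br)cc3)C2=O)cc(OC)c1OC` keeps the bromo group of compound 2 and makes one change: methoxy in place of hydrogen on an aromatic carbon. Methoxy replaces hydrogen on an aromatic carbon, ortho to two methoxy groups and para to a large group. Within the data shown here, the only measured step, a 1.2-fold lower number from compound 1 to compound 2 (0.09 log units; within the scatter), exchanged chloro for bromo at another place and stayed within the scatter. Among the measured compounds shown here, it says little about this change, and no measured pair tests an added methoxy. No step beyond the scatter is therefore expected in this assay, in either direction, though the uncertainty is wide. The estimated step is a 1.1-fold lower number from compound 2 to compound 3 (0.03 log units; within the scatter). For compound 3 the expected value is 4500 nM, within an estimated range of 1800 nM to 11000 nM.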

Compound 3, half-maximal inhibitory concentration: 6800 nM
For compound 3 the middle estimate is 1.5-fold (0.18 log units) below the measured one; the range from low to high includes it.
By their numbers in this assay, from the lowest: compounds 2, 1 and 3 (each within the scatter of the next).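

Among these compounds, the added methoxy gives the first direct reading at this place on the ring: in this assay the change yields a 1.4-fold higher number from compound 2 to compound 3 (0.15 log units; within the scatter) and so leaves the two numbers indistinguishable. A methoxy group ortho to two methoxy groups and para to a large group therefore fits on this bromo compound without a change that can be told from ordinary assay noise. No independent evidence here helps explain this result.

Still open, on these data alone, is whether a different group at this same place, such as an amine, a carboxylic acid or a longer chain, would move the number beyond the scatter. Also open is whether the same added methoxy would give a similar result on the chloro compound, compound 1, for which no such partner is shown.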